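Swapping Phenethyl for Diethylamino on the Side Chain

A few compounds are considered here, and "the series" means these few. Any claim that something is new, unique, unknown or untested is made for them only; others in the source may bear on it.

Measured compounds:
compound 1 `CCCCNc1nc(N)nc(C)c1CCCN1CCN(C)CC1` gives 179 nM in an assay on HEK293 cells for agonist activity at Toll-like receptor 8 (Homo sapiens), read by spectrophotometry; a lower number here means that less compound is needed, a higher number that more compound is needed for the effect
compound 2 `CCCCNc1nc(N)nc(C)c1CCCC(C)(C)O` gives 1220 nM in this assay
compound 3 `CCCCNc1nc(N)nc(C)c1CCCCCc1ccccc1` gives 830 nM in this assay

Compound 3 stands second highest of these three numbers; compound 2 is within the scatter of it, while compound 1 lies clearly lower (a 4.6-fold higher number from compound 1 to compound 3 (0.67 log units; beyond the scatter)). Compound 4 `CCCCNc1nc(N)nc(C)c1CCCN(CC)CC` arises from compound 3 by diethylamino in place of phenethyl on a saturated chain carbon, three bonds along the chain from an aromatic carbon. Among the measured compounds shown here, the only step that bears on it is the one in which the nitrogen-containing group of compound 1 gave way to phenethyl (a 4.6-fold higher number from compound 1 to compound 3 (0.67 log units; beyond the scatter)); the change to compound 4 brings a nitrogen-containing group back to the same place. The expectation is therefore a step of a 3.8-fold lower number from compound 3 to compound 4 (0.58 log units; beyond the scatter) in this assay, toward a lower number. For compound 4 the estimated value is 220 nM, ranging from 70 nM to 650 nM.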

Compound 4, half-maximal effective concentration: 254 nM
Beside the measured number, compound 4's estimate is 1.2-fold (0.06 log units) below it; the range from low to high includes it.
By their numbers in this assay, from the lowest: compounds 1 and 4 (each within the scatter of the next); then compounds 3 and 2 (each within the scatter of the next).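

In this assay, a second nitrogen-containing group at this place goes with a lower number (a 3.3-fold lower number from compound 3 to compound 4 (0.51 log units; beyond the scatter)), and the same holds against the alcohol-bearing side chain (a 4.8-fold lower number from compound 2 to compound 4 (0.68 log units; beyond the scatter)). The diethylamino and 4-methylpiperazin-1-yl groups cannot be told apart here (a 1.4-fold higher number from compound 1 to compound 4 (0.15 log units; within the scatter)), so an open-chain group and a ring group with nitrogen give matching results. Among these four compounds, none goes against this pairing of nitrogen with the lower numbers.

No evidence on the cause is available. As far as these compounds go, whether a primary amine, a carboxylic acid or a longer chain before the nitrogen would fit this pattern remains open.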